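Swapping Methoxy for Hydroxyl on a Triazole Series

This account rests on a few compounds, and the source may have more. Where it says the series, first, only, none or still open, it means among the compounds named here.

Compound 1 `O=C1O/C(=C\Cn2cc(-c3ccc(Br)cc3)nn2)C(OCc2ccccc2)=C1OCc1ccccc1` and compound 2 `COc1ccc(-c2cn(C/C=C3\OC(=O)C(OCc4ccccc4)=C3OCc3ccccc3)nn2)cc1` share one core and differ only in the group carried on the phenyl ring. In an ADME assay on HFF cells (Homo sapiens) for cytotoxicity, read by MTT assay, with a stated time of 72 h (a lower number here means a stronger inhibitor, a higher number a weaker inhibitor), compound 1 gives > 100000 nM, which is a limit of the assay rather than a number. In this assay compound 2 gives > 100000 nM, again a limit of the assay. Within the data shown here, the step that the two limits leave unreadable from compound 1 to compound 2 therefore cannot be read, because both ends sit at the limit of > 100000 nM in this assay, at which 2 of the 2 values shown sit, and that is where compound 2 stands: at the limit, with the one other value shown being a limit as well.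

Compound 3 `O=C1O/C(=C\Cn2cc(-c3cccc(O)c3)nn2)C(OCc2ccccc2)=C1OCc1ccccc1` is the unmeasured partner, made from compound 2 by 3-hydroxyphenyl in place of 4-methoxyphenyl on an aromatic carbon. Among the measured compounds shown here, the only measured step is unreadable, so no measured step tells how this change moves this assay. The expectation rests on compound 2 alone and its value > 100000 nM. Compound 3 is expected to give about 150000 nM, between 60000 nM and 400000 nM, and most likely to be reported only as a limit again. The step that the limit leaves unreadable from compound 2 to compound 3 is expected to be none beyond the scatter.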

Compound 3, half-maximal inhibitory concentration: 42600 nM
Compound 3: the middle estimate sits 3.5-fold (0.55 log units) above what was measured, and the stated range ends above it.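

The earlier pair could not show whether the group on this carbon of the five-membered aromatic ring with 3 nitrogen matters at all in this assay, since the step between their two limits cannot be read. Bringing in 3-hydroxyphenyl settles that, giving an at least 2.3-fold lower number from compound 2 to compound 3 (0.37 log units; beyond the scatter) and also an at least 2.3-fold lower number from compound 1 to compound 3 (0.37 log units; beyond the scatter), and both sizes are minimum sizes, so the real steps may be larger. Compound 3 is the only one of the three compounds with a measured number rather than a limit, so it gives this series its first readable point: the limit of > 100000 nM in this assay, at which 2 of the 3 values shown sit.

From the compounds shown here alone, what stays open is which part of the change carries the step, since the entering group differs from 4-methoxyphenyl both in having a hydroxyl in place of a methoxy and in where that group sits on the phenyl ring. Neither 4-hydroxyphenyl nor 3-methoxyphenyl is among the compounds shown, and they would separate those two parts, while an amine or a carboxylic acid on the same phenyl ring would show whether other groups also bring the number down.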